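A few compounds are considered here, and "the series" means these few. Any claim that something is new, unique, unknown or untested is made for them only; others in the source may bear on it.

Working notes on the series in a functional assay on Caco-2 cells (Homo sapiens) for cytotoxicity, read by cell counting, with a stated time of 48 h; on this read-out higher numbers stand for weaker inhibition and lower numbers for stronger inhibition. Going by the values given here, compound 1 (`Cc1ccc(-n2cc(COc3cccc4cnc(Nc5cccc(Cl)c5)nc34)nn2)c([N+](=O)[O-])c1`) gives 37000 nM and compound 2 (`Clc1ccc(-n2cc(COc3cccc4cnc(Nc5cccc(Cl)c5)nc34)nn2)cc1`) gives 24000 nM, so compound 2 stands level with the only other measured member. Among the compounds with values here, the single measured step, a 1.5-fold lower number from compound 1 to compound 2 (0.19 log units; within the scatter), lies within the scatter.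

Compound 3 (`COc1ccccc1-n1cc(COc2cccc3cnc(Nc4cccc(Cl)c4)nc23)nn1`) carries 2-methoxyphenyl in place of 4-chlorophenyl on an aromatic nitrogen. Within the data shown here, the change falls at the same place as the measured step, so that step is the only evidence bearing on it. Among the measured compounds shown here, it is thin evidence, and no measured compound carries a 2-methoxyphenyl group.

The expected change in this assay is therefore no larger than the scatter, with no firm direction: the estimate is a 1.2-fold higher number from compound 2 to compound 3 (0.07 log units; within the scatter). For compound 3 the expected value is 28000 nM, with an estimated range of 12000 nM to 60000 nM.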

Compound 3, half-maximal inhibitory concentration: > 25000 nM
Compound 3 ended at the assay's limit (the forecaster's own chance of this, stated with the estimate: 10%); the middle value is on the limit's open side.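

In this assay compound 3 ended at a limit of the assay, not at a number: the limit of > 25000 nM in this assay, at which 1 of the 3 values shown sits.

Only a floor can be given for the readable step, an at least 1.0-fold higher number from compound 2 to compound 3 (0.01 log units; that floor lies within the scatter), so 2-methoxyphenyl on the aromatic nitrogen cannot be separated from 4-chlorophenyl, and the step from compound 1 to compound 3 cannot be read. From the compounds shown here alone, the new information is one-sided: with its hydrogen-bond acceptor, 2-methoxyphenyl shows no stronger inhibition at this position, while how much weaker it may be stays unknown.

Going by these compounds, whether any group on this nitrogen can move the number beyond the scatter stays open. All three groups shown are substituted phenyl rings, so a phenyl ring bearing an aminomethyl group or a carboxylic acid, or a benzyl group in place of the phenyl ring, would extend the comparison.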